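Glycine Ester Analogue in the Tail Flick Series

The source may hold more compounds than are shown below. What is called first, only, known or untested is meant among the compounds shown, and "the series" means these compounds.

Measured in a functional assay on the whole organism (Tail, strain ICR) with Mus musculus as the target, in the tail flick test, with a stated time of 90 min, at a dose of 25 umol/kg by the oral route; on this read-out higher numbers stand for a stronger effect at the one dose given and lower numbers for a weaker effect:
compound 1 `CC(C)[C@H](NC(=O)CN(c1ncnc2c1ncn2C1CCCCO1)C1CC1)C(=O)OCc1ccccc1` gives 30.1%
compound 2 `CSCC[C@H](NC(=O)CN(c1ncnc2c1ncn2C1CCCCO1)C1CC1)C(=O)OCc1ccccc1` gives 42.7%
compound 3 `C[C@H](NC(=O)CN(c1ncnc2c1ncn2C1CCCCO1)C1CC1)C(=O)OCc1ccccc1` gives 32.1%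

Compound 3 stands second highest of the three numbers; its nearest neighbour is compound 1, with a number 2 percentage points higher from compound 1 to compound 3 (within the scatter), and its furthest is compound 2, with a number 10.6 percentage points lower from compound 2 to compound 3 (beyond the scatter). Compound 4 `O=C(CN(c1ncnc2c1ncn2C1CCCCO1)C1CC1)NCC(=O)OCc1ccccc1` is not yet measured and differs from compound 3 by hydrogen in place of methyl on a saturated chain carbon bound to an amide-type nitrogen and a carbonyl carbon. Among the measured compounds shown here, two measured steps bear on this shortening of the side chain: a number 2 percentage points higher from compound 1 to compound 3 (within the scatter), which stayed within the scatter, and a number 10.6 percentage points lower from compound 2 to compound 3 (beyond the scatter), a larger shortening that brought a modest loss. Removing the last carbon is therefore expected to bring no change beyond the scatter or a small drop, a number 5.1 percentage points lower from compound 3 to compound 4 (within the scatter). Compound 4 is estimated at 27%, with a range from 17% to 38%.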

Compound 4, a percentage reported as activity, at one dose (the size of the read-out at that dose, not a potency): 25.9%
Compound 4: middle estimate off by 1.1 percentage points, on the high side; measured number inside the range.
By their numbers in this assay, from the lowest: compounds 4, 1 and 3 (each within the scatter of the next); then compound 2.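

In this assay, hydrogen in place of methyl at this saturated chain carbon stays within the scatter (a number 6.2 percentage points lower from compound 3 to compound 4 (within the scatter)), as does hydrogen in place of isopropyl (a number 4.2 percentage points lower from compound 1 to compound 4 (within the scatter)). Loss of the whole side chain therefore separates only the 2-(methylsulfanyl)ethyl compound from the glycine ester (a number 16.8 percentage points lower from compound 2 to compound 4 (beyond the scatter)). No measurement shown explains this difference.

As far as these compounds go, whether the sulfur atom or the chain length sets compound 2 apart remains open. A straight butyl chain, or an amine or a carboxylic acid at this position, would address this.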